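Replacing bromo with cyano on compound 2

The source may hold more compounds than are shown below. What is called first, only, known or untested is meant among the compounds shown, and "the series" means these compounds.

Compound 1 `COc1cc(/C=C2\CN(C)C/C(=C\c3ccccc3F)C2=O)cc(OC)c1OC`: 12100 nM
Compound 2 `COc1cc(/C=C2\CN(C)C/C(=C\c3ccc(Br)cc3)C2=O)cc(OC)c1OC`: 15400 nM

In an ADME assay on L02 cells (Homo sapiens) for cytotoxicity, read by MTT assay, with a stated time of 24 h (on this read-out lower numbers stand for stronger inhibition and higher numbers for weaker inhibition), compound 2 gives 15400 nM, which matches compound 1 within the scatter. Compound 3 `COc1cc(/C=C2\CN(C)C/C(=C\c3ccc(C#N)cc3)C2=O)cc(OC)c1OC`, not yet measured, differs from compound 2 at a single place, with cyano in place of bromo on an aromatic carbon. Going by the values given here, only one measured step bears on this change: a 1.3-fold higher number from compound 1 to compound 2 (0.10 log units; within the scatter), with 4-bromophenyl in place of 2-fluorophenyl. Among the compounds with values here, that step is small, but it involves a different pair of groups, and no measured compound carries cyano, so the evidence is thin. On the strength of that single step, no shift beyond the scatter is expected in this assay. The expected step is a 1.1-fold lower number from compound 2 to compound 3 (0.04 log units; within the scatter). Compound 3 is estimated at 14000 nM, with an expected range from 7000 nM to 28000 nM.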

Compound 3, half-maximal inhibitory concentration: 18600 nM
Estimate against measurement, compound 3: 1.3-fold (0.12 log units) below; the measured number falls inside the stated range.
By their numbers in this assay, from the lowest: compounds 1, 2 and 3 (each within the scatter of the next).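

Cyano on an aromatic carbon para to a large group is the first group shown at this place that is not a halogen, and in this assay its exchange for bromo gives a 1.2-fold higher number from compound 2 to compound 3 (0.08 log units; within the scatter) and so stays within the scatter. Set against the 2-fluorophenyl group, the 4-cyanophenyl group gives a 1.5-fold higher number from compound 1 to compound 3 (0.19 log units; within the scatter) and also stays within the scatter, so all three aryl groups shown read alike in this assay despite differing in both group and place. Nothing shown gives a reason for this flat result.

As far as these compounds go, whether an amine or a carboxylic acid on this ring would move the number beyond the scatter stays open. So does whether the picture holds once the rest of the shared core is changed, as that part is the same in all three compounds.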